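The compounds below may be only part of what the source reports. "The series", "measured", "known", "first", "only" and "open" are said of these compounds alone.

Compound 1 `O=C(CCCC1CCN(C(=O)C2CCCCC2)CC1)c1ncco1` and compound 2 `O=C(CCCC1CCN(C(=O)CCC2CCCCC2)CC1)c1ncco1` share a core and differ only in the group attached to the carbonyl carbon on the ring nitrogen. In an assay on isolated protein for inhibition of Fatty-acid amide hydrolase 1 (Homo sapiens) (a lower number here means a stronger inhibitor, a higher number a weaker inhibitor), compound 1 gives 45 nM and compound 2 gives 3 nM. Going by the values given here, compound 1 thus stands at the higher of the two numbers, the weaker inhibitor of the pair; the single step of a 15-fold lower number from compound 1 to compound 2 (1.18 log units; beyond the scatter) shows a large gain from a longer group on that carbonyl.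

Compound 3 `Cc1ccc(CN2CCC(CCCC(=O)c3ncco3)CC2)cc1` is not yet measured. Relative to compound 1 it carries a different change: 4-methylbenzyl in place of cyclohexylcarbonyl on an amine nitrogen in a ring. Among the compounds with values here, no measured step touches this kind of exchange, in which the carbonyl itself is lost; the one known step concerns only the group on that carbonyl. The expectation therefore rests on little, and the estimate for compound 3 is 200 nM with a range of 40 nM to 1000 nM, meaning an expected step of a 4.4-fold higher number from compound 1 to compound 3 (0.65 log units; beyond the scatter) toward a weaker inhibitor.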

Compound 3, half-maximal inhibitory concentration: 400 nM
Estimate against measurement, compound 3: 2.0-fold (0.30 log units) below; the range from low to high includes it.
By their numbers in this assay, from the lowest: compound 2; then compound 1; then compound 3.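

In this assay, the group on the ring nitrogen matters for more than the length of what sits on its carbonyl: 4-methylbenzyl in place of cyclohexylcarbonyl gives an 8.9-fold higher number from compound 1 to compound 3 (0.95 log units; beyond the scatter), toward a weaker inhibitor. The two groups hold the same count of heavy atoms, so that count alone does not set the number here; the exchange removes the carbonyl and its hydrogen-bond acceptor and also replaces a non-aromatic ring with an aromatic one. Nothing available explains the loss.

Which of these two differences counts remains open. Cyclohexylmethyl on the ring nitrogen would keep the non-aromatic ring without the carbonyl, while 4-methylbenzoyl would keep the carbonyl with the aromatic ring.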